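A few compounds are considered here, and "the series" means these few. Any claim that something is new, unique, unknown or untested is made for them only; others in the source may bear on it.

In a functional assay on KB cells (Homo sapiens) for antiproliferative activity, read by colorimetric assay and MTT assay (on this read-out higher numbers stand for weaker inhibition and lower numbers for stronger inhibition), compound 1 `O=S(=O)(Nc1cccc2cc[nH]c12)c1ccc(Cl)cc1` gives 6 ug/mL and compound 2 `O=S(=O)(Nc1ccc(Cl)c2cc[nH]c12)c1ccc(Cl)cc1` gives 9.7 ug/mL, so these two stand within the scatter of each other. Compound 3 `O=S(=O)(Nc1cccc2cc(O)[nH]c12)c1ccc(Cl)cc1` gives 1.1 ug/mL, the number furthest from compound 1 among the three measured.

Compound 4 `Nc1ccc(S(=O)(=O)Nc2cccc3cc[nH]c23)cc1` has not yet been measured. It keeps the core of compound 1 and carries amino in place of chloro on an aromatic carbon, para to a large group: amino in place of chloro on an aromatic carbon.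

Within the data shown here, no measured step makes this exchange, so the evidence is only indirect. Both measured steps put a new group in place of hydrogen at other places on the core. Chloro gives a 1.6-fold higher number from compound 1 to compound 2 (0.21 log units; within the scatter), while hydroxy gives a 5.5-fold lower number from compound 1 to compound 3 (0.74 log units; beyond the scatter). Together they show that a single-group change on this core can leave the number within the scatter or move it modestly, and the one move seen beyond the scatter is towards a lower number. A small step is therefore expected in this assay, quite possibly none beyond the scatter, with only a slight lean towards a lower number. Expressed as a step, the estimate is a 1.2-fold lower number from compound 1 to compound 4 (0.08 log units; within the scatter). For compound 4 the estimated value is 5 ug/mL, with an expected range of 1.5 ug/mL to 16 ug/mL.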

Compound 4, half-maximal inhibitory concentration: 36 ug/mL
For compound 4 the middle estimate is 7.2-fold (0.86 log units) below the measured one; measured number above the stated range.
By their numbers in this assay, from the lowest: compound 3; then compounds 1 and 2 (each within the scatter of the next); then compound 4.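

In this assay, the exchange of chloro for amino on an aromatic carbon, para to a large group, gives a 6.0-fold higher number from compound 1 to compound 4 (0.78 log units; beyond the scatter), so a change of a single heavy atom at this place is enough to move the number beyond the scatter. Among these compounds, until now the only step beyond the scatter was the one at another place on the core, a 5.5-fold lower number from compound 1 to compound 3 (0.74 log units; beyond the scatter), which went towards stronger inhibition, whereas this one goes towards weaker inhibition, so the direction of a single-group change on this scaffold depends on the place or the group involved. Nothing available on these compounds accounts for the size or the direction of this step.

The compounds shown leave open whether the step reflects the loss of the chloro, the arrival of the amino or both, since none of them carries hydrogen at this place, and how a methoxy, a methyl or a carboxylic acid there would read in this assay. Also open, as far as these compounds go, is whether the hydroxy on the core would bring the same move towards a lower number when the amino is present in place of the chloro.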